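The source may report more compounds than this note shows. Statements on the series, on what has been measured and on what is new or still open speak of the compounds shown alone.

Of the compounds shown here, two sharing one core have been measured in a functional assay on MCF7 cells (Homo sapiens) for cytotoxicity, read by MTT assay, with a stated time of 96 h; on this read-out lower numbers stand for stronger inhibition and higher numbers for weaker inhibition. There, compound 1 (`COc1cc(C(=O)c2cn(-c3ccccc3)cc2-c2ccccc2Br)cc(OC)c1OC`) gives 190 nM and compound 2 (`COc1cc(C(=O)c2cn(-c3cccc(C)c3)cc2-c2ccccc2F)cc(OC)c1OC`) gives 190 nM, so compound 2 stands level with compound 1 at the digits shown. Compound 3 (`COc1cc(C(=O)c2cn(-c3cccc(C)c3)cc2-c2ccc(N)cc2)cc(OC)c1OC`) is the next to be tested in this assay. It carries 4-aminophenyl in place of 2-fluorophenyl on an aromatic carbon of a five-membered aromatic ring with 1 nitrogen, next to the ring atom that bears a large group (4-aminophenyl in place of 2-fluorophenyl on an aromatic carbon). Among the measured compounds shown here, no measured pair differs in one place only, so the data offer no direct guide to the size of this change. A moderate move toward stronger inhibition is nevertheless expected, an estimated step of a 3.2-fold lower number from compound 2 to compound 3 (0.50 log units; beyond the scatter), though the uncertainty is wide. For compound 3 the expected value is 60 nM, with an estimated range from 12 nM to 300 nM.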

Compound 3, half-maximal inhibitory concentration: 18 nM
Compound 3: the middle estimate sits 3.3-fold (0.52 log units) above what was measured, within the range that was stated.
By their numbers in this assay, from the lowest: compound 3; then compounds 1 and 2 (each within the scatter of the next).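

In this assay, this aromatic carbon of the five-membered aromatic ring with 1 nitrogen proves sensitive to what it carries: 4-aminophenyl in place of 2-fluorophenyl gives an 11-fold lower number from compound 2 to compound 3 (1.02 log units; beyond the scatter). Neither the heavy-atom count nor the six-membered aromatic ring of carbon only changes between the two groups, so a large step arises here without any change in the size of the group, while the entering group adds a hydrogen-bond donor and acceptor. Nothing measured here explains the step.

The compounds shown leave open whether the amine itself or its place on the phenyl ring carries the step; a 4-fluorophenyl or a 2-aminophenyl group would separate the two. Also open, on these data alone, is how a hydroxyl or a methoxy group at the same place on that ring would compare.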